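The source may report more compounds than this note shows. Statements on the series, on what has been measured and on what is new or still open speak of the compounds shown alone.

Compound 3, `NC(=O)COc1ccc2c(c1)S(=O)(=O)N=C(c1c(O)c(-c3cccs3)nn(CC3CCC3)c1=O)N2`, gives 0.367 h in an in vitro ADME assay on microsomes from liver (Homo sapiens) for metabolic stability; a lower number here means that the compound disappears faster, a higher number that the compound lasts longer. Of the three numbers measured, its number is the largest, yet neither gap to a neighbour is one the assay can resolve: the step of a 1.8-fold higher number from compound 1 to compound 3 (0.26 log units; within the scatter) and the step of a 1.0-fold higher number from compound 2 to compound 3 (0.02 log units; within the scatter) both lie within the scatter. Compound 1, `NC(=O)COc1ccc2c(c1)S(=O)(=O)N=C(c1c(O)c(-c3cccs3)nn(CCC3CC3)c1=O)N2`, gives 0.2 h in this assay, and compound 2, `CC(C)(C)CCn1nc(-c2cccs2)c(O)c(C2=NS(=O)(=O)c3cc(OCC(N)=O)ccc3N2)c1=O`, gives 0.35 h; the step of a 1.8-fold higher number from compound 1 to compound 2 (0.24 log units; within the scatter) is also within the scatter. All three measured compounds differ only in the group on the saturated chain carbon bound to the aromatic nitrogen, and none of those exchanges moved the half-life beyond the scatter.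

Compound 4, `NC(=O)COc1ccc2c(c1)S(=O)(=O)N=C(c1c(O)c(-c3cccs3)nn(CC3CCCC3)c1=O)N2`, continues in the same place: cyclopentyl in place of cyclobutyl on a saturated chain carbon bound to an aromatic nitrogen. Going by the values given here, the steps that bear on it are the three above, each within the scatter, so no step beyond the scatter is expected in this assay, in either direction. He therefore expects compound 4 to sit close to compound 3, with the step of a 1.0-fold higher number from compound 3 to compound 4 (0.00 log units; within the scatter) amounting to no real change. His estimate for compound 4 in this assay is 0.37 h, with a range from 0.2 h to 0.7 h.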

Compound 4, half-life: 0.433 h
Estimate against measurement, compound 4: 1.2-fold (0.07 log units) below, and the stated range covers the measured number.
By their numbers in this assay, from the lowest: compounds 1, 2, 3 and 4 (each within the scatter of the next, the first and the last beyond it).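

In this assay, cyclopentyl at this place on a saturated chain carbon bound to an aromatic nitrogen gives no readable difference from cyclobutyl, with a 1.2-fold higher number from compound 3 to compound 4 (0.07 log units; within the scatter), or from neopentyl, with a 1.2-fold higher number from compound 2 to compound 4 (0.09 log units; within the scatter). Going by these compounds alone, what the earlier compounds did not show is a step at this place that clears the scatter: a 2.2-fold higher number from compound 1 to compound 4 (0.34 log units; beyond the scatter), a modest step from cyclopropylmethyl to cyclopentyl, although compound 2 and compound 3 remain within the scatter of compound 4, so the separation holds only between the two ends of the set and does not establish a trend with ring size. Nothing shown here accounts for that modest step.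

As far as these compounds go, all four compounds carry only carbon and hydrogen in this group, so it remains open whether an amine, a carboxylic acid or a longer chain at the same place would give a step larger than this one. Within the data shown here, because every comparison here changes only this group, it also remains open whether a change elsewhere on the shared core would do more for the half-life than any exchange at this place.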